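The source may report more compounds than this note shows. Statements on the series, on what has been measured and on what is new or still open speak of the compounds shown alone.

Of the compounds shown here, three have numbers so far in a functional assay on MCF7 cells (Homo sapiens) for antiproliferative activity, read by MTT assay, with a stated time of 48 h; a higher number here means a weaker inhibitor, a lower number a stronger inhibitor. Compound 1 `CC(=O)OC/C1=C/C[C@](C)(CCC=C(C)C)/C=C/[C@@H](OC(=O)C=C(C)C)[C@](C)(O)/C=C/C1=O` gives 4510 nM and compound 2 `CC(=O)OC/C1=C/C[C@](C)(CCC=C(C)C)/C=C/[C@@H](OC(=O)C=C(C)C)[C@](C)(OC(C)=O)/C=C/C1=O` gives 3990 nM, a pair that does not separate: a 1.1-fold lower number from compound 1 to compound 2 (0.05 log units; within the scatter). Compound 3 `CC(C)=CCC[C@]1(C)/C=C/[C@@H](OC(=O)C=C(C)C)[C@](C)(O)/C=C/C(=O)/C(C(=O)O)=C\C1` stands highest of the three at 16100 nM, making it the weakest so far.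

Compound 4 `CC(C)=CCC[C@]1(C)/C=C/[C@@H](OC(=O)C=C(C)C)[C@](C)(O)/C=C/C(=O)/C(CN(C(C)C)C(C)C)=C\C1` departs from compound 3 at one place: (diisopropylamino)methyl in place of carboxy on a double-bonded ring carbon. This puts (diisopropylamino)methyl in place of carboxy on a double-bonded ring carbon. For the measured compounds named here, only one measured step concerns that carbon, a 3.6-fold higher number from compound 1 to compound 3 (0.55 log units; beyond the scatter), with carboxy in place of acetoxymethyl. The acetyl step lies elsewhere on the core and does not bear on this change. Going by the values given here, no measured compound carries the (diisopropylamino)methyl group, so the expectation rests on that single modest step and stays loose.

A fall of similar size is expected on leaving carboxy, which would return the number to the region of compound 1 at 4510 nM. The estimated move in this assay is a 3.2-fold lower number from compound 3 to compound 4 (0.51 log units; beyond the scatter). For compound 4 the expected value is 5000 nM, with an estimated range of 1500 nM to 14000 nM.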

Compound 4, half-maximal inhibitory concentration: 780 nM
The estimate for compound 4 lay 6.4-fold (0.81 log units) above the measured number, outside the stated range (below it).
By their numbers in this assay, from the lowest: compound 4; then compounds 2 and 1 (each within the scatter of the next); then compound 3.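

In this assay, for the compounds shown here, this double-bonded ring carbon carries more weight than the earlier compounds showed: the change to (diisopropylamino)methyl gives a 21-fold lower number from compound 3 to compound 4 (1.31 log units; beyond the scatter) and, against the acetoxymethyl compound, gives a 5.8-fold lower number from compound 1 to compound 4 (0.76 log units; beyond the scatter) so the new group goes past the level of compound 1 rather than returning to it. Among the compounds shown, every step beyond the scatter falls on this carbon, while the acetyl step elsewhere on the core stays within it. Nothing available here accounts for the gain.

A dimethylaminomethyl or a morpholinomethyl group on the same carbon would show whether the step belongs to amines generally or to the diisopropylamino group alone. Also open, from the compounds shown here alone, is whether the acetoxy group of compound 2 keeps its flat result when paired with the (diisopropylamino)methyl group.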